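A few compounds are considered here, and "the series" means these few. Any claim that something is new, unique, unknown or untested is made for them only; others in the source may bear on it.

In an assay on isolated protein (Cricetulus griseus) for binding affinity to Alpha-1B adrenergic receptor (Mesocricetus auratus), read by radioligand binding (on this read-out higher numbers stand for weaker inhibition and lower numbers for stronger inhibition), compound 1 `O=S(=O)(Nc1cccc2c1CCCC2c1c[nH]cn1)C1CC1` has no exact number: its value < 10000 nM is a limit of the assay, as shown by the limit of < 10000 nM in this assay, at which 1 of the 2 values shown sits. Compound 2 `O=S(=O)(Nc1cccc2c1CCCC2c1c[nH]cn1)c1ccc2ccccc2c1` in this assay gives 214 nM. Compound 3 `Oc1cccc2c1CCCC2c1c[nH]cn1` has not been measured yet; it differs from compound 1 in one place, (hydroxy in place of (cyclopropylsulfonyl)amino on an aromatic carbon). With compound 1 giving only a limit, no direction can be read from it. The step that the limit leaves unreadable from compound 1 to compound 3 is expected to be modest, with either direction possible. Compound 3 is estimated at 2500 nM, within a range from 400 nM to 10000 nM.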

Compound 3, inhibition constant: 145 nM
Beside the measured number, compound 3's estimate is 17-fold (1.24 log units) above it, and the stated range ends above it.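

Going by these compounds alone, no step from compound 1 to compound 3 can be read, because compound 1 has only a limit and no exact number: the limit of < 10000 nM in this assay, at which 1 of the 3 values shown sits. The compounds shown leave open how large the change in this assay is when hydroxy takes the place of (cyclopropylsulfonyl)amino, and in which direction it runs.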